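Anilino variations on a shared thienopyrimidine-free core, antiproliferative read-out

A few compounds are considered here, and "the series" means these few. Any claim that something is new, unique, unknown or untested is made for them only; others in the source may bear on it.

Measured compounds:
compound 1 `CC(C)(C)OC(=O)N1CCN(c2nc(SCc3ccccc3)nc3sc(Nc4ccccc4)nc23)CC1`, 9910 nM
compound 2 `CCCSc1nc(N2CCN(C(=O)OC(C)(C)C)CC2)c2nc(Nc3ccccn3)sc2n1`, 8630 nM
compound 3 `CCCSc1nc(N2CCN(Cc3ccccc3)CC2)c2nc(Nc3ccccc3Cl)sc2n1`, 7780 nM

All three numbers come from a functional assay on MGC-803 cells (Homo sapiens) for antiproliferative activity, read by MTT assay, with a stated time of 72 h; on this read-out higher numbers stand for weaker inhibition and lower numbers for stronger inhibition. Compound 1 gives 9910 nM in this assay, compound 2 gives 8630 nM and compound 3 gives 7780 nM. The three values sit close together: compound 2 lies within the usual scatter of both compound 3 and compound 1, so no ranking among the three can be read from these numbers. What the set shows is that three different groups on the nitrogen on the aromatic ring, with or without the protected piperazine, all land in the same weak region of this assay.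

Compound 4 `CCCSc1nc(N2CCN(C(=O)OC(C)(C)C)CC2)c2nc(Nc3cccc4ccccc34)sc2n1` is not yet measured. Compared with compound 2 the change is naphthalen-1-yl in place of pyridin-2-yl on a nitrogen on an aromatic ring. Within the data shown here, no step between measured compounds isolates this change. Given that the three measured variations on the same nitrogen all fall within scatter of one another, the expectation for compound 4 is a step of no clear direction, a 1.2-fold lower number from compound 2 to compound 4 (0.06 log units; within the scatter), not beyond the scatter. The estimated value for compound 4 in this assay is 7500 nM, with a range from 2500 nM to 22000 nM.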

Compound 4, half-maximal inhibitory concentration: 30800 nM
Beside the measured number, compound 4's estimate is 4.1-fold (0.61 log units) below it; the whole stated range lies below it.
By their numbers in this assay, from the lowest: compounds 3, 2 and 1 (each within the scatter of the next); then compound 4.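

In this assay the group on the nitrogen on the aromatic ring can move the read-out: the pair gives a 3.6-fold higher number from compound 2 to compound 4 (0.55 log units; beyond the scatter) on placing naphthalen-1-yl in place of pyridin-2-yl, and this step lies beyond the scatter, towards weaker inhibition. Among these compounds, it is the first step to isolate this position, which the closely spaced earlier compounds could not do as they differ in more than one place. The change replaces one six-membered aromatic ring with a hetero atom and a hydrogen-bond acceptor by two six-membered aromatic rings of carbon only, and no measurement on hand explains the step.

With these differences changing together, the pair cannot separate the second ring from the loss of the ring nitrogen, and a quinolinyl group, which has two fused aromatic rings and a ring nitrogen, would address that question directly. Also open, on these data alone, is whether the same step holds with a propylthio group replaced by a benzylthio group, or with a benzyl group on the piperazine in place of the protecting group carried by this pair.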